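Swapping chloro for fluoro on the tetrazole-bearing analogue

The source may report more compounds than this note shows. Statements on the series, on what has been measured and on what is new or still open speak of the compounds shown alone.

Measured so far:
compound 1, `O=C(CSc1ncccn1)N/N=c1/scc(-c2ccc(F)cc2)n1-c1ccccc1`, 32.2%
compound 2, `O=C(CSc1nnnn1-c1ccccc1)N/N=c1/scc(-c2ccc(Cl)cc2)n1-c1ccccc1`, 52.4%

In a functional assay on C6 cells (Rattus norvegicus) for cytotoxicity, read by MTT assay, with a stated time of 24 h, tested at 200 ug/mL (a higher number here means a weaker effect of the compound at the concentration tested, a lower number a stronger effect), compound 2 gives the higher of the two numbers; compound 1 gives 32.2%, and the gap between them lies beyond the scatter. Compound 3, `O=C(CSc1nnnn1-c1ccccc1)N/N=c1/scc(-c2ccc(F)cc2)n1-c1ccccc1`, has not been measured. Its change from compound 2 is fluoro in place of chloro on an aromatic carbon, read one bond further out as 4-chlorophenyl to 4-fluorophenyl. For the measured compounds named here, no measured pair shows this change alone, so the expected step of a number 8.4 percentage points lower from compound 2 to compound 3 (within the scatter) is modest and downward, hardly beyond the scatter. Compound 3 is estimated at 44%, within 28% to 62%.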

Compound 3, a percentage reported as activity, at one concentration (the size of the read-out at that concentration, not a potency): 30.6%
Compound 3: the middle estimate sits 13.4 percentage points above what was measured, within the range that was stated.
By their numbers in this assay, from the lowest: compounds 3 and 1 (each within the scatter of the next); then compound 2.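

For the compounds shown here, on the 4-chlorophenyl to 4-fluorophenyl change alone, this assay gives a number 21.8 percentage points lower from compound 2 to compound 3 (beyond the scatter) and this is the first isolated reading of this para position, showing that fluoro in place of chloro on this aromatic carbon matters here. With fluoro held in place, 1-phenyl-1H-tetrazol-5-yl in place of pyrimidin-2-yl on the sulfur gives a number 1.6 percentage points lower from compound 1 to compound 3 (within the scatter) and so separates the two sulfur groups no further. No evidence at hand accounts for either step.

The compounds shown leave open how bromo, methoxy or plain hydrogen would read on this aromatic carbon. They also leave open whether chloro and fluoro part in the same way with pyrimidin-2-yl on the sulfur.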